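Ethoxy for fluoro on the acid-bearing core

This account rests on a few compounds, and the source may have more. Where it says the series, first, only, none or still open, it means among the compounds named here.

Three compounds of this series have numbers in a functional assay on Hep 3B2 cells (Homo sapiens) for antiproliferative activity, read by MTT assay, with a stated time of 24 h, tested at 3.7 ug/mL; on this read-out higher numbers stand for a stronger effect at the one concentration tested and lower numbers for a weaker effect. Compound 3 `Cc1c(C(=O)Nc2c(F)cc(-c3cccc(F)c3)cc2F)nc2ccc(F)cc2c1C(=O)O` gives 11.2% and stands second highest of the three. Compound 2 `Cc1ccc2nc(C(=O)Nc3c(F)cc(-c4cccc(F)c4)cc3F)c(C)c(C(=O)O)c2c1` gives 31.3%, and the change from compound 2 to compound 3, fluoro in place of methyl on an aromatic carbon, is a number 20.1 percentage points lower from compound 2 to compound 3 (beyond the scatter), beyond the scatter. Among the measured compounds shown here, compound 1 `CCOc1ccc2nc(C(=O)Nc3c(F)cc(-c4cccc(F)c4)cc3F)c(C)c(O)c2c1` gives 1.56%; its gap to compound 3 lies within the scatter, and it differs from compound 3 in two places, so no single step is drawn from it.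

Compound 4 `CCOc1ccc2nc(C(=O)Nc3c(F)cc(-c4cccc(F)c4)cc3F)c(C)c(C(=O)O)c2c1` differs from compound 3 as follows: ethoxy in place of fluoro on an aromatic carbon. For the measured compounds named here, the one measured step at this aromatic carbon, a number 20.1 percentage points lower from compound 2 to compound 3 (beyond the scatter), shows that the group on this carbon moves the read-out in this assay by a modest amount. It does not speak to ethoxy directly; compound 1 carries ethoxy but differs in a second place as well, so its value gives no clean reading. Only a loose expectation follows: a step of a number 10.8 percentage points higher from compound 3 to compound 4 (beyond the scatter) is estimated, leaning upward because the step of a number 20.1 percentage points lower from compound 2 to compound 3 (beyond the scatter) ran downward when fluoro entered. Compound 4 is therefore expected to give about 22%, with a range from 4% to 40%.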

Compound 4, a percentage reported as inhibition, at one concentration (the size of the read-out at that concentration, not a potency): 26.5%
The estimate for compound 4 lay 4.5 percentage points below the measured number; the range from low to high includes it.
By their numbers in this assay, from the lowest: compounds 1 and 3 (each within the scatter of the next); then compounds 4 and 2 (each within the scatter of the next).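

In this assay on the shared core, ethoxy in place of fluoro on this aromatic carbon gives a number 15.3 percentage points higher from compound 3 to compound 4 (beyond the scatter), while ethoxy in place of methyl gives a number 4.8 percentage points lower from compound 2 to compound 4 (within the scatter), so ethoxy and methyl cannot be told apart here and, of the three groups on this carbon, fluoro alone stands apart from the other two. Among the compounds shown here, a second position also becomes readable for the first time: with ethoxy held in place, carboxy in place of hydroxy on an aromatic carbon gives a number 24.9 percentage points higher from compound 1 to compound 4 (beyond the scatter), a step that compound 1 could not offer against any earlier partner. No supporting data bear on why these steps run as they do.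

Still open, from the compounds shown here alone, is how an amine, a chlorine or a longer alkoxy chain such as butoxy would read on this aromatic carbon, and whether any of them would pass the level shared by the methyl and ethoxy compounds. Also open, going by these compounds, is whether the carboxy-for-hydroxy step holds with fluoro or methyl on the ring, as hydroxy appears here only alongside ethoxy, and whether a methyl ester or a primary amide in place of carboxy would keep the higher number.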